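A few compounds are considered here, and "the series" means these few. Any claim that something is new, unique, unknown or untested is made for them only; others in the source may bear on it.

In a functional assay on HeLa cells (Homo sapiens) for cytotoxicity, read by MTT assay, with a stated time of 2 days (on this read-out lower numbers stand for stronger inhibition and higher numbers for weaker inhibition), compound 1 `CCN(CC)c1ccc2nc(-c3cccc4ccccc34)[nH]c(=O)c2c1` gives 4 nM, the lowest of the two numbers measured here. The nearest number belongs to compound 3 `Cc1cccc(-c2nc3cc(C)ccc3c(=O)[nH]2)c1`, which in this assay gives 11200 nM, a gap well beyond the scatter. Compound 2 `Cc1ccc2nc(-c3cccc(F)c3)[nH]c(=O)c2c1` yields only a limit of the assay rather than a number, > 50000 nM; this is the limit of > 50000 nM in this assay, at which 1 of the 3 values shown sits. Compound 4 `CN(C)c1ccc2nc(-c3cccc4ccccc34)[nH]c(=O)c2c1` is the untested counterpart of compound 1, differing in one place: dimethylamino in place of diethylamino on an aromatic carbon. Among the compounds with values here, no measured pair isolates such a change, so the step from compound 1 to compound 4 is expected to be small, most likely within the scatter or slightly toward weaker inhibition. For compound 4 the estimate in this assay is 8 nM, with a range from 2 nM to 40 nM. The step of a 2.0-fold higher number from compound 1 to compound 4 (0.30 log units; within the scatter) that this estimate means is expected to stay within the scatter.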

Compound 4, half-maximal inhibitory concentration: 50 nM
For compound 4 the middle estimate is 6.3-fold (0.80 log units) below the measured one; the measured number lies above the stated range.
By their numbers in this assay, from the lowest: compound 1; then compound 4; then compound 3. At a limit, above all of these: compound 2.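

In this assay, replacing diethylamino with dimethylamino on this aromatic carbon gives a 13-fold higher number from compound 1 to compound 4 (1.10 log units; beyond the scatter). This is the first pair shown that differs in one place, and it shows that this position is sensitive to the change from 5 heavy atoms to 3, even though the hydrogen-bond counts stay the same. Nothing shown accounts for the step. Open, on these data alone, is whether dipropylamino would extend this trend, and how a pyrrolidine, a morpholine or a primary amine on the same carbon would compare with diethylamino.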